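The source may report more compounds than this note shows. Statements on the series, on what has been measured and on what is new or still open speak of the compounds shown alone.

Measured so far:
Compound 1 `COC(=O)CC(=O)N1N=C(c2ccc(-n3cncn3)cc2)CC1c1ccc(N(C)C)cc1`: in a functional assay on NCI-H1975 cells (Homo sapiens) for inhibition, read by sulforhodamine B assay, tested at 10 uM (on this read-out higher numbers stand for more inhibition at the one concentration tested (going by the name of the read-out) and lower numbers for less inhibition), compound 1 gives 1.5%.
Compound 2 `CN(C)c1ccc(C2CC(c3ccc(-n4cncn4)cc3)=NN2C(=O)c2cc(Cl)cc(Cl)c2)cc1`: in this assay compound 2 gives 8.4%.
Compound 3 `CN(C)c1ccc(C2CC(c3ccc(-n4cncn4)cc3)=NN2C(=O)/C=C/c2ccccc2)cc1`: in this assay compound 3 gives -2.3%.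

Compound 3 holds the lowest of the three numbers; its gap to compound 1 is within the scatter, while a number 10.7 percentage points lower from compound 2 to compound 3 (beyond the scatter). Compound 4 `CN(C)c1ccc(C2CC(c3ccc(-n4cncn4)cc3)=NN2S(C)(=O)=O)cc1` differs from compound 3 by methylsulfonyl in place of (2-phenylethenyl)carbonyl on an amine nitrogen in a ring. For the measured compounds named here, none of the measured steps tests such a change: each of them, a number 6.9 percentage points higher from compound 1 to compound 2 (within the scatter), a number 3.8 percentage points lower from compound 1 to compound 3 (within the scatter) and a number 10.7 percentage points lower from compound 2 to compound 3 (beyond the scatter), exchanges one group for another on the carbonyl carbon, and all three measured compounds sit near the bottom of the read-out. Going by the values given here, the methylsulfonyl group has no precedent among them, so compound 4 is expected to show no more than a number 5.3 percentage points higher from compound 3 to compound 4 (within the scatter). The estimate for compound 4 is 3%, ranging from -8% to 14%.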

Compound 4, a percentage reported as inhibition, at one concentration (the size of the read-out at that concentration, not a potency): -3.1%
The estimate for compound 4 lay 6.1 percentage points above the measured number; low and high end bracket the measured number.
By their numbers in this assay, from the lowest: compounds 4, 3, 1 and 2 (each within the scatter of the next, the first and the last beyond it).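

In this assay, putting methylsulfonyl on the amine nitrogen in a ring, a group with no carbonyl, gives a number 0.8 percentage points lower from compound 3 to compound 4 (within the scatter) and a number 4.6 percentage points lower from compound 1 to compound 4 (within the scatter), so the read-out does not separate it from those two carbonyl-linked groups. The step from the (3,5-dichlorophenyl)carbonyl compound, a number 11.5 percentage points lower from compound 2 to compound 4 (beyond the scatter), is the only one of the three beyond the scatter. Nothing at hand explains these numbers.

On these data alone, whether a phenylsulfonyl group or an amine-bearing chain on this nitrogen would read differently stays open. As far as these compounds go, the 4-(dimethylamino)phenyl and 4-(1H-1,2,4-triazol-1-yl)phenyl groups are the same throughout, so what changing either would do is also open.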